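The compounds below may be only part of what the source reports. "The series", "measured", "known", "first", "only" and "open" are said of these compounds alone.

For the measured compounds named here, compound 1 `O=c1c(Cl)c(CSC(=S)N2CCOCC2)oc2ccccc12` is the weaker of the two measured members: in a functional assay on LM7 cells (Homo sapiens) for antiproliferative activity, read by MTT assay, with a stated time of 72 h (on this read-out lower numbers stand for stronger inhibition and higher numbers for weaker inhibition), compound 1 gives 19200 nM, the highest of the two numbers, while compound 2 `COc1ccc2occ(CSC(=S)N(C(C)C)C(C)C)c(=O)c2c1` gives 4700 nM in this assay, a lower number that lies beyond the scatter. The two differ in several places at once, so no single step can be read from them. Compound 3 `O=c1c(Cl)c(CSC(=S)N2CCCCC2)oc2ccccc12` differs from compound 1 in one place only: piperidin-1-yl in place of morpholin-4-yl on a thiocarbonyl carbon. Going by the values given here, no comparable step is available among the measured pair, so the step from compound 1 to compound 3 is expected to be small, a 1.5-fold lower number from compound 1 to compound 3 (0.17 log units; within the scatter), most likely within the scatter. Compound 3 is therefore estimated at 13000 nM in this assay, with a range from 4500 nM to 40000 nM.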

Compound 3, half-maximal inhibitory concentration: 3300 nM
Compound 3: the middle estimate sits 3.9-fold (0.60 log units) above what was measured; the measured number lies below the stated range.
By their numbers in this assay, from the lowest: compounds 3 and 2 (each within the scatter of the next); then compound 1.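

For the compounds shown here, exchanging morpholin-4-yl for piperidin-1-yl on a thiocarbonyl carbon is the first single-place change readable, and in this assay it gives a 5.8-fold lower number from compound 1 to compound 3 (0.76 log units; beyond the scatter). The activity at this position therefore responds to the ring itself, even though both rings have the same size and the same heavy-atom count. Nothing at hand bears on the reason for this step.

On these data alone, what pyrrolidin-1-yl or 4-methylpiperazin-1-yl would give at this position remains open. So does whether the step carries over to the core of compound 2.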